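A few compounds are considered here, and "the series" means these few. Any claim that something is new, unique, unknown or untested is made for them only; others in the source may bear on it.

Measured compounds:
- compound 1, `NC(=O)c1c(NC(=O)c2ccccc2Cl)sc2c1CCN(Cc1ccc([N+](=O)[O-])cc1)C2`: 31500 nM
- compound 2, `NC(=O)c1c(NC(=O)c2ccccc2F)sc2c1CCN(Cc1c(Cl)cccc1Cl)C2`: 7430 nM

These two values come from a functional assay on MKN-74 cells (Homo sapiens) for antiproliferative activity, with a stated time of 24 h; a higher number here means a weaker inhibitor, a lower number a stronger inhibitor. Compound 1 has the higher of the two numbers, so it is the weaker inhibitor of the pair, and the gap between the value of compound 1 and that of compound 2 is beyond the usual scatter of this assay. Compound 2 differs from compound 1 in more than one place, so no single structural change can be tied to that gap; the two values simply show where each stands.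

The unmeasured compound 3, `NC(=O)c1c(NC(=O)c2ccccc2Cl)sc2c1CCN(C(=S)Nc1ccccc1Br)C2`, is reached from compound 1 by one change: a group of 10 heavy atoms (7 carbon, 1 nitrogen, 1 sulfur, 1 bromine; one six-membered aromatic ring of carbon only) in place of a group of 10 heavy atoms (7 carbon, 1 nitrogen, 2 oxygen; one six-membered aromatic ring of carbon only), on an amine nitrogen in a ring. Going by the values given here, no pair of measured compounds shows the effect of a change of this kind, so there is no measured step to lean on; what remains is the position of compound 1 and the structural change itself. Given that, a step of modest size is expected, toward a lower number, but it could well fall within the scatter. For compound 3 the expected value in this assay is 20000 nM, with a range from 5000 nM to 60000 nM, which corresponds to an expected step of a 1.6-fold lower number from compound 1 to compound 3 (0.20 log units; within the scatter).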

Compound 3, half-maximal inhibitory concentration: 10800 nM
For compound 3 the middle estimate is 1.9-fold (0.27 log units) above the measured one, within the range that was stated.
By their numbers in this assay, from the lowest: compounds 2 and 3 (each within the scatter of the next); then compound 1.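

In this assay, the substituent on the amine nitrogen in the ring now has its first measured single change: replacing 4-nitrobenzyl with the group that carries sulfur and bromine gives a 2.9-fold lower number from compound 1 to compound 3 (0.46 log units; beyond the scatter). Compound 1 and compound 2 could not show this because they differ in more than one place, whereas here the rest of the molecule stays the same, so the shift belongs to this swap alone. The step shows that the number at this position responds to the choice of group even when the two groups have the same number of heavy atoms and each holds a six-membered aromatic ring of carbon only, though nothing measured here explains why the number falls.

The swap alters several things at once, including the atoms that link the aromatic ring to the nitrogen, the substituent on that ring and the presence of a hydrogen-bond donor, so the compounds shown cannot say which of these matters. From the compounds shown here alone, it also remains open how the number would move with a plain benzyl group, or with a carboxylic acid or an amine on the aromatic ring.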